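Adding a Fluoro Group on the Far Side of Compound 1

This account rests on a few compounds, and the source may have more. Where it says the series, first, only, none or still open, it means among the compounds named here.

Compound 1 `Cc1ccccc1N(C)C(=O)c1ccc(-c2ccc(OS(N)(=O)=O)cc2)o1` carries a sulfamate on one end and a methylated amide on the other. In an assay on T47D cells for inhibition of Steryl-sulfatase (Homo sapiens), read by HPLC, with a stated time of 24 h (a higher number here means a weaker inhibitor, a lower number a stronger inhibitor), compound 1 gives 28 nM. Two relatives have also been measured. Compound 2 `Cc1ccccc1N(C)C(=O)c1ccc(-c2ccc(OS(N)(=O)=O)c(Cl)c2)o1` gives 25 nM in this assay, and compound 3 `Cc1cc(-c2ccc(C(=O)N(C)c3ccccc3C)o2)ccc1OS(N)(=O)=O` gives 570 nM. Among these three numbers compound 1 stands second highest: the step of a 1.1-fold lower number from compound 1 to compound 2 (0.05 log units; within the scatter) is within the scatter, whereas the step of a 20-fold higher number from compound 1 to compound 3 (1.31 log units; beyond the scatter) is large.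

Compound 4 `Cc1ccc(F)cc1N(C)C(=O)c1ccc(-c2ccc(OS(N)(=O)=O)cc2)o1` is reached from compound 1 by the change (fluoro in place of hydrogen on an aromatic carbon). Both measured steps, a 1.1-fold lower number from compound 1 to compound 2 (0.05 log units; within the scatter) and a 20-fold higher number from compound 1 to compound 3 (1.31 log units; beyond the scatter), place their change on the ring bearing the sulfamate, not on the ring where the fluoro enters. For the measured compounds named here, no measured step touches this ring, so there is no direct precedent for the change. A single small fluoro group is therefore expected to leave the number close to that of compound 1, with no step beyond the scatter: the estimated step is no change at the digits printed from compound 1 to compound 4 (within the scatter). Compound 4 is estimated at 28 nM, with a range from 12 nM to 65 nM.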

Compound 4, half-maximal inhibitory concentration: 40 nM
Compound 4: the middle estimate sits 1.4-fold (0.15 log units) below what was measured; the measured number falls inside the stated range.
By their numbers in this assay, from the lowest: compounds 2, 1 and 4 (each within the scatter of the next); then compound 3.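

For the compounds shown here, the earlier compounds changed only the ring bearing the sulfamate, so compound 4 gives the first reading on the other aromatic ring: in this assay, going from 2-methylphenyl to 5-fluoro-2-methylphenyl gives a 1.4-fold higher number from compound 1 to compound 4 (0.15 log units; within the scatter). At this place, meta to a large group and para to a methyl group, a fluoro group therefore leaves the number indistinguishable from that of compound 1, unlike the large step seen with the methyl group on the sulfamate ring, a 20-fold higher number from compound 1 to compound 3 (1.31 log units; beyond the scatter). Nothing available here gives a measured reason for this result.

One fluoro group says nothing about how a larger or very different group would fare at the same place, such as an amine, a carboxylic acid or a longer chain. As far as these compounds go, it is also open whether a fluoro group elsewhere on this ring would leave the number just as unchanged.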